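Swapping bromo for a hydroxypiperidinyl on the benzoylguanidine

The compounds below may be only part of what the source reports. "The series", "measured", "known", "first", "only" and "open" are said of these compounds alone.

Measured compounds:
compound 1 `CCc1cc(Br)c(S(C)(=O)=O)cc1C(=O)N=C(N)N` gives 41 nM
compound 2 `CCN(CC)Cc1cc(Br)c(S(C)(=O)=O)cc1C(=O)N=C(N)N` gives 9500 nM
compound 3 `CS(=O)(=O)c1cc(C(=O)N=C(N)N)ccc1Br` gives 180 nM

In a functional assay for inhibition of sodium/hydrogen exchanger (Oryctolagus cuniculus) (on this read-out lower numbers stand for stronger inhibition and higher numbers for weaker inhibition), compound 1 holds the lowest number of the three. The two shown steps away from compound 1 both raise the number: a 230-fold higher number from compound 1 to compound 2 (2.36 log units; beyond the scatter) and a 4.4-fold higher number from compound 1 to compound 3 (0.64 log units; beyond the scatter), and between the other two compounds a 53-fold lower number from compound 2 to compound 3 (1.72 log units; beyond the scatter). Compound 4 `CCc1cc(N2CCC(O)CC2)c(S(C)(=O)=O)cc1C(=O)N=C(N)N` differs from compound 1 in one place: 4-hydroxypiperidin-1-yl in place of bromo on an aromatic carbon. No measured step touches the position carrying the bromo, so neither shown step bears directly on this change; they only show that the core tolerates some change at other positions with a modest cost and a large one elsewhere. An entering ring of this size is a larger change than either shown step, so a modest rise beyond the scatter is expected. Compound 4 is therefore estimated at 150 nM with a range of 30 nM to 800 nM. That expectation corresponds to a step of a 3.7-fold higher number from compound 1 to compound 4 (0.56 log units; beyond the scatter).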

Compound 4, half-maximal inhibitory concentration: 41 nM
For compound 4 the middle estimate is 3.7-fold (0.56 log units) above the measured one, and the stated range covers the measured number.
By their numbers in this assay, from the lowest: compounds 1 and 4 (each within the scatter of the next); then compound 3; then compound 2.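

In this assay, the aromatic carbon ortho to a methylsulfonyl group takes 4-hydroxypiperidin-1-yl in place of bromo with no change at the digits printed from compound 1 to compound 4 (within the scatter). The earlier compounds shown here all kept bromo here, so they could not show that a six-membered non-aromatic ring with 1 hetero atom, along with a hydrogen-bond donor, can enter at this place where no ring stood, while the read-out stays level. Nothing available explains this result.

The compounds shown do not separate the contribution of the ring from that of its hydroxyl, so the outcome with an unsubstituted piperidin-1-yl, a morpholin-4-yl or a carboxylic acid at this place remains open. Also open, on these data alone, is whether the same swap would hold on the core of compound 3, which carries hydrogen in place of ethyl.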